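The compounds below may be only part of what the source reports. "The series", "measured", "known", "first", "only" and "open" are said of these compounds alone.

Measured compounds:
- compound 1 `O=c1cc(-c2ccccc2)oc2ccc(OCCCCCCN3CCCCC3)cc12`: 101 nM in an assay on isolated protein (Cavia porcellus) with Sigma non-opioid intracellular receptor 1 (Homo sapiens) as the target, read by radioligand binding; a higher number here means a weaker inhibitor, a lower number a stronger inhibitor
- compound 2 `CCOC(=O)C1CCN(CCCCCCOc2ccc3oc(-c4ccccc4)cc(=O)c3c2)CC1`: in this assay compound 2 gives 164 nM

Compound 1 stands as the lower of the two numbers in this assay; its nearest neighbour is compound 2, and the step of a 1.6-fold higher number from compound 1 to compound 2 (0.21 log units; within the scatter) lies within the scatter, so the two are not separated by the data.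

Compound 3 `O=c1cc(C2CCCCC2)oc2ccc(OCCCCCCN3CCCCC3)cc12` differs from compound 1 in one place: cyclohexyl in place of phenyl on an aromatic carbon. Among the compounds with values here, the only measured step, a 1.6-fold higher number from compound 1 to compound 2 (0.21 log units; within the scatter), concerns an ethoxycarbonyl on a saturated ring carbon at the other end of the shared core and does not touch the aromatic carbon where the phenyl sits, so no measured step bears directly on the change to cyclohexyl. The series therefore gives no evidence for a step beyond the scatter in this assay in either direction from this exchange.

Compound 3 is expected to give about 100 nM in this assay, within a range of 30 nM to 350 nM, which corresponds to an expected step of a 1.0-fold lower number from compound 1 to compound 3 (0.00 log units; within the scatter).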

Compound 3, half-maximal inhibitory concentration: 55 nM
Compound 3: middle estimate off by 1.8-fold (0.26 log units), on the high side; the measured number falls inside the stated range.
By their numbers in this assay, from the lowest: compounds 3, 1 and 2 (each within the scatter of the next, the first and the last beyond it).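

Within the data shown here, replacing phenyl with cyclohexyl on the aromatic carbon next to the ring oxygen gives a 1.8-fold lower number from compound 1 to compound 3 (0.26 log units; within the scatter) in this assay, which is the first measured step at this position of the shared core. The two groups are both six-membered rings of carbon only, with 6 heavy atoms each, so this pair tests an aromatic ring against a non-aromatic one, and the outcome is not separated from the scatter: within this pair, an aromatic ring at this carbon is not needed for a number of this order. Nothing on hand gives a reason for the size of this step.

The compounds shown leave open whether this carbon accepts anything other than a six-membered ring of carbon only, such as a methyl, a tert-butyl, a pyridyl ring or a phenyl carrying a fluorine, and whether any of these would move the number beyond the scatter. Also open, on these data alone, is whether cyclohexyl in place of phenyl gives a step of similar size when the ethoxycarbonyl of compound 2 is present.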